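The source may report more compounds than this note shows. Statements on the series, on what has been measured and on what is new or still open speak of the compounds shown alone.

Measured compounds:
Compound 1 `O=S(=O)(Nc1ccc(-c2nc3ccccc3o2)cc1)c1ccc(Cl)s1` gives 31000 nM in an assay on cells for inhibition of HSP60/HSP10 (Homo sapiens), with a stated time of 60 min; on this read-out higher numbers stand for weaker inhibition and lower numbers for stronger inhibition.
Compound 2 `O=S(=O)(Nc1ccc(-c2nc3ccccc3o2)cc1)c1cccs1` gives 63000 nM in this assay.
Compound 3 `O=S(=O)(Nc1ccc(-c2nc3ccccc3o2)cc1)c1ccc(O)cc1` gives 78000 nM in this assay.

Compound 3 holds the highest of the three numbers. Against compound 2 the gap is a 1.2-fold higher number from compound 2 to compound 3 (0.09 log units; within the scatter), within the scatter, so no order between those two can be read. Against compound 1 the gap is a 2.5-fold higher number from compound 1 to compound 3 (0.40 log units; beyond the scatter), beyond the scatter, so compound 1 has the lower number of that pair.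

Compound 4 `COc1ccccc1S(=O)(=O)Nc1ccc(-c2nc3ccccc3o2)cc1` differs from compound 3 in one place: 2-methoxyphenyl in place of 4-hydroxyphenyl on a sulfonyl sulfur. Within the data shown here, no measured step exchanges one six-membered aromatic ring of carbon only for another on the sulfonyl sulfur. Among the measured compounds shown here, the steps that bear on it are those that exchange the group on that sulfur: a 2.5-fold higher number from compound 1 to compound 3 (0.40 log units; beyond the scatter), modest and beyond the scatter, and a 1.2-fold higher number from compound 2 to compound 3 (0.09 log units; within the scatter), within the scatter. The step of a 2.0-fold higher number from compound 1 to compound 2 (0.31 log units; beyond the scatter) touches only the chloro and shows how far a small change on the group at that sulfur can move the number. On this basis the change from compound 3 to compound 4 is expected to be small, most likely within the scatter, with a slight lean toward a lower number given that compound 3 holds 78000 nM, the highest of the three. Compound 4 is therefore estimated at 60000 nM, within 20000 nM to 160000 nM, an expected step of a 1.3-fold lower number from compound 3 to compound 4 (0.11 log units; within the scatter).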

Compound 4, half-maximal inhibitory concentration: > 100000 nM
Compound 4: a limit, no number (the forecaster's own chance of this, stated with the estimate: 20%); middle value at least 1.6-fold (0.22 log units) from the limit.
By their numbers in this assay, from the lowest: compound 1; then compounds 2 and 3 (each within the scatter of the next). At a limit, above all of these: compound 4.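

In this assay compound 4 stands at a limit and not at a number: the limit of > 100000 nM in this assay, at which 1 of the 4 values shown sits.

Among these compounds, this is the first exchange of one six-membered aromatic ring of carbon only for another on the sulfonyl sulfur, and the only step of the three that can be read as an order is an at least 3.2-fold higher number from compound 1 to compound 4 (0.50 log units; beyond the scatter), which places the 2-methoxyphenyl compound on the higher side of the 5-chlorothiophen-2-yl compound. The other two, an at least 1.2-fold higher number from compound 3 to compound 4 (0.10 log units; that floor lies within the scatter) and an at least 1.5-fold higher number from compound 2 to compound 4 (0.20 log units; that floor lies within the scatter), have floors within the scatter, so they fix no order, but they do show that 2-methoxyphenyl, which carries 0 hydrogen-bond donors against 1 on the 4-hydroxyphenyl it replaces, gives no lower number in this series.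

Two things differ between these groups at once, the hydroxyl giving way to methoxy and the place of the substituent on the ring. 4-methoxyphenyl or 2-hydroxyphenyl on the sulfonyl sulfur would be needed to tell them apart. Also open, on these data alone, is how an amine or a carboxylic acid on that phenyl ring would compare with the 5-chlorothiophen-2-yl of compound 1, whose 31000 nM is the lowest value shown.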